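Swapping the aryl group on the shared core

The compounds below may be only part of what the source reports. "The series", "measured", "known", "first", "only" and "open" are said of these compounds alone.

Compound 2 `COc1ccccc1C1C(C#N)=C(N)N(c2ccc(S(N)(=O)=O)cc2)C2=C1C(=O)CCC2` stands lowest of the two numbers measured in a functional assay on Ehrlich cells (Mus musculus) for antiproliferative activity, read by trypan blue exclusion, with a stated time of 2 h, tested at 10 ug/mL (a lower number here means a weaker effect, a higher number a stronger effect of the compound at the concentration tested), where compound 2 gives 0%. Compound 1 `Cc1ccc(C2C(C#N)=C(N)N(c3ccc(S(N)(=O)=O)cc3)C3=C2C(=O)CCC3)cc1` gives 30% in this assay. Compound 3 `N#CC1=C(N)N(c2ccc(S(N)(=O)=O)cc2)C2=C(C(=O)CCC2)C1c1ccc([N+](=O)[O-])cc1` differs from compound 2 by 4-nitrophenyl in place of 2-methoxyphenyl on a saturated ring carbon. Among the measured compounds shown here, the one measured step that bears on this change is a number 30 percentage points lower from compound 1 to compound 2 (beyond the scatter), a swap of the aryl group at the same place. Because compound 2 already gives 0%, the step can only go upward or stay within the scatter, and the estimated step is a number 20 percentage points higher from compound 2 to compound 3 (beyond the scatter). Compound 3 is therefore expected to give 20%, in a range from 0% to 45%.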

Compound 3, a percentage reported as activity, at one concentration (the size of the read-out at that concentration, not a potency): 85%
For compound 3 the middle estimate is 65 percentage points below the measured one; measured number outside the range, above it.
By their numbers in this assay, from the lowest: compound 2; then compound 1; then compound 3.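

In this assay, among the compounds shown here, the result shows that the aryl group on this saturated ring carbon can carry far more of the read-out than the earlier compounds suggested, with 4-nitrophenyl in place of 2-methoxyphenyl giving a number 85 percentage points higher from compound 2 to compound 3 (beyond the scatter). The cleaner comparison, nitro in place of methyl on an aromatic carbon, still gives a number 55 percentage points higher from compound 1 to compound 3 (beyond the scatter). Nothing given here accounts for this gain. On these data alone, whether 2-nitrophenyl would hold this level remains open, as does whether an amine or a carboxylic acid in place of the nitro group would.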